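A few compounds are considered here, and "the series" means these few. Any claim that something is new, unique, unknown or untested is made for them only; others in the source may bear on it.

Compound 1, `Cc1ccc(-c2cnn3c(NCc4ccccn4)cc(C)nc23)cc1`: in a physicochemical assay for solubility, read by HPLC, using the shake flask method, measured as kinetic solubility, with a stated time of 2 h, at pH 7.4 (on this read-out lower numbers stand for lower solubility and higher numbers for higher solubility), compound 1 gives < 5000 nM, which is a limit of the assay rather than a number.
Compound 2, `COc1ccc(-c2cnn3c(NCc4ccccn4)cc(C)nc23)cc1`: in this assay compound 2 gives < 5000 nM, again a limit.
Compound 3, `Cc1cc(NCc2ccccn2)n2ncc(-c3ccc(F)cc3F)c2n1`: in this assay compound 3 gives < 5000 nM, also a limit.

Compound 3 therefore stands nowhere definite on the numbers shown: its value is a limit, and the two other values are limits as well, so no compound can be set above or below another. The steps a step that the two limits leave unreadable from compound 1 to compound 2, a step that the two limits leave unreadable from compound 1 to compound 3 and a step that the two limits leave unreadable from compound 2 to compound 3 are all unreadable for the same reason, as the limit of < 5000 nM in this assay, at which 3 of the 3 values shown sit, records.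

Compound 4, `Cc1cc(NCc2ccccn2)n2ncc(C3=CCC(F)(F)CC3)c2n1`, differs from compound 3 by one change: 4,4-difluorocyclohex-1-en-1-yl in place of 2,4-difluorophenyl on an aromatic carbon. Among the compounds with values here, no measured step bears on this change, and none of the measured steps has a readable size, so the size and direction of the step that the limit leaves unreadable from compound 3 to compound 4 in this assay can only be estimated from the fact that every compound so far sits at the limit. Compound 4 is expected to give about 3000 nM, within 500 nM to 15000 nM, most probably reported as a limit once more.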

Compound 4, solubility: 5000 nM
Beside the measured number, compound 4's estimate is 1.7-fold (0.22 log units) below it; the range from low to high includes it.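

In this assay, within the data shown here, compound 4 gives 5000 nM, the first result here that is a number and not a limit, with 4,4-difluorocyclohex-1-en-1-yl at the place where the earlier compounds carry an aromatic ring. The entering and leaving groups hold the same carbon and fluorine atoms, so the change at this position lies in the ring itself, now non-aromatic with a double bond. The new steps are a number no lower from compound 3 to compound 4 (the limit leaves the size open), a number no lower from compound 2 to compound 4 (the limit leaves the size open) and a number no lower from compound 1 to compound 4 (the limit leaves the size open), so they give a direction but no size: the limit of < 5000 nM in this assay, at which 3 of the 4 values shown sit.

The steps among compound 1, compound 2 and compound 3 cannot be read. As far as these compounds go, whether the double bond or the two fluorines matter stays open, as does how an amine or a carboxylic acid at this place would read in this assay.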